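Trading a Nitro Group for Two Fluorines

The source may report more compounds than this note shows. Statements on the series, on what has been measured and on what is new or still open speak of the compounds shown alone.

Of the compounds shown here, two have been measured so far. Compound 1 `Cc1nc(N(C)C(=O)NC(=O)c2c(F)cccc2F)sc1C(=O)N/N=C/c1ccccc1C(F)(F)F` and compound 2 `CN(C(=O)NC(=O)c1cccc([N+](=O)[O-])c1)c1nc(C(F)(F)F)c(C(=O)N/N=C/c2ccccc2C(F)(F)F)s1` share a common core but differ from each other in more than one place, so no single structural step can be read off between them. In a functional assay on HepG2 cells (Homo sapiens) for inhibition, read by MTT assay, with a stated time of 72 h (a lower number here means a stronger inhibitor, a higher number a weaker inhibitor), compound 1 gives 1.11 ug/mL, while compound 2 gives 4.8 ug/mL, the higher of the two numbers, and the gap between them is larger than the usual scatter of repeated measurements.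

Compound 3 `CN(C(=O)NC(=O)c1ccc(F)c(F)c1)c1nc(C(F)(F)F)c(C(=O)N/N=C/c2ccccc2C(F)(F)F)s1` is not yet measured. It differs from compound 2 in one place only: 3,4-difluorophenyl in place of 3-nitrophenyl on a carbonyl carbon. Within the data shown here, no measured pair shows this exact change, so the expectation must rest on the two values at hand. Since compound 1 shows that a lower number is reachable on this core, and since both compounds carry fluorines on their aryl groups, a modest move downward seems the most reasonable expectation, though a result within the scatter of compound 2 cannot be excluded. The expected step of a 1.6-fold lower number from compound 2 to compound 3 (0.20 log units; within the scatter) is therefore small. The estimate for compound 3 is 3 ug/mL, with a range from 1.2 ug/mL to 8 ug/mL.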

Compound 3, half-maximal inhibitory concentration: 10.4 ug/mL
Estimate against measurement, compound 3: 3.5-fold (0.54 log units) below; measured number outside the range, above it.
By their numbers in this assay, from the lowest: compound 1; then compound 2; then compound 3.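

Among these compounds, this is the first comparison on the shared core that changes one place only. In this assay, 3,4-difluorophenyl in place of 3-nitrophenyl, on a carbonyl carbon whose other neighbour is an amide-type nitrogen, gives a 2.2-fold higher number from compound 2 to compound 3 (0.34 log units; beyond the scatter), so the group at this position does affect the read-out and this exchange yields a weaker inhibitor. Compound 1 differs from the other two compounds in more than one place, so steps involving it cannot be read and its lower number cannot be credited to any single group, while nothing measured here accounts for the step between compound 2 and compound 3.

The compounds shown leave open whether the step reflects the departure of the nitro group or the arrival of the two fluorines, a question that a plain phenyl group at the same place could help to separate. They also leave open how a phenyl ring carrying an amine or a carboxylic acid would behave here, and whether this exchange gives a step of similar size on the core of compound 1.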